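The source may report more compounds than this note shows. Statements on the series, on what has been measured and on what is new or still open speak of the compounds shown alone.

Measured so far in a functional assay on MIA PaCa-2 cells (Homo sapiens) for cytotoxicity, read by MTT assay, with a stated time of 72 h; a lower number here means a stronger inhibitor, a higher number a weaker inhibitor:
- compound 1 `C#CCn1cc(C(=O)NC(CC(=O)Nc2ccccc2)c2ccccc2)c(=O)c2cc(F)c(Cl)nc21` gives 6900 nM
- compound 2 `C#CCn1cc(C(=O)NC(CC(=O)NC2CCCCC2)c2ccccc2)c(=O)c2cc(F)c(Cl)nc21` gives 4900 nM

Within the data shown here, compound 1 and compound 2 lie within the scatter of each other in this assay; the single step between them, a 1.4-fold lower number from compound 1 to compound 2 (0.15 log units; within the scatter), changes only the amide substituent and carries no information about the fused core.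

Compound 3 `C#CCn1cc(C(=O)NC(CC(=O)Nc2ccccc2)c2ccccc2)c(=O)c2ccc(Cl)nc21` is the next member. It differs from compound 1 by hydrogen in place of fluoro on an aromatic carbon. Among the measured compounds shown here, none of the measured steps touches this position of the core, so there is no precedent to scale the effect of this change. In the absence of such precedent the step from compound 1 to compound 3 is expected to stay within the scatter, estimated as a 1.3-fold higher number from compound 1 to compound 3 (0.12 log units; within the scatter), with a wide allowance either way. Compound 3 is therefore expected to give about 9000 nM in this assay, in the range 3500 nM to 25000 nM.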

Compound 3, half-maximal inhibitory concentration: 3000 nM
Beside the measured number, compound 3's estimate is 3.0-fold (0.48 log units) above it; the whole stated range lies above it.
By their numbers in this assay, from the lowest: compounds 3, 2 and 1 (each within the scatter of the next, the first and the last beyond it).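

In this assay, among these compounds, the change of fluoro to hydrogen on this aromatic carbon, ortho to the chloro group, gives a 2.3-fold lower number from compound 1 to compound 3 (0.36 log units; beyond the scatter) and is the first step to lie beyond the scatter. The fluoro group is therefore not required for the activity of compound 1 against these cells, and its removal brings a modest gain rather than a loss. No available evidence bears on why this step runs in this direction.

The compounds shown leave open whether the same step would appear with the cyclohexyl amide of compound 2, as the change is seen only with the phenyl amide. They also leave open how this carbon would respond to a larger or different group, such as methoxy, an amine or a nitrile.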